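From a Hydroxyethyl Group to a Carboxylic Acid

The source may report more compounds than this note shows. Statements on the series, on what has been measured and on what is new or still open speak of the compounds shown alone.

Compound 1 `CC(O)c1cc(-c2ccccc2)c2ccc(OCc3cccc(C4(O)CCOCC4)c3)cc2c1` gives 28 nM in a functional assay for inhibition, with Homo sapiens as the target; a higher number here means a weaker inhibitor, a lower number a stronger inhibitor.
Compound 2 `CC(=O)c1cc(-c2ccccc2)c2ccc(OCc3cccc(C4(O)CCOCC4)c3)cc2c1` gives 2 nM in this assay.

Of the two measured compounds, compound 1 stands at the higher number in this assay, which means it is the weaker inhibitor of the pair. Within the data shown here, the one measured step, a 14-fold lower number from compound 1 to compound 2 (1.15 log units; beyond the scatter), shows that swapping the group at this position on the shared core can shift the read-out strongly.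

Compound 3 `O=C(O)c1cc(-c2ccccc2)c2ccc(OCc3cccc(C4(O)CCOCC4)c3)cc2c1` is the next member of the series. It differs from compound 1 by carboxy in place of 1-hydroxyethyl on an aromatic carbon. Among the measured compounds shown here, no measured step covers a carboxy group, so the step from compound 1 to compound 2 bears on the new compound only by showing that this position is sensitive, not in which direction a carboxy group would move the number. For the measured compounds named here, with only that indirect guide, the expectation is a modest change at most, well within the reach of the scatter, and a wide range is needed. Compound 3 is therefore estimated at 40 nM, with a range from 8 nM to 200 nM, an expected step of a 1.4-fold higher number from compound 1 to compound 3 (0.15 log units; within the scatter).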

Compound 3, half-maximal inhibitory concentration: 190 nM
Compound 3: the middle estimate sits 4.8-fold (0.68 log units) below what was measured, within the range that was stated.
By their numbers in this assay, from the lowest: compound 2; then compound 1; then compound 3.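

In this assay compound 3 is the weakest inhibitor of the three, so this position now shows a penalty as well as a gain: carboxy in place of 1-hydroxyethyl gives a 6.8-fold higher number from compound 1 to compound 3 (0.83 log units; beyond the scatter) and hydroxy in place of methyl on the carbonyl carbon gives a 95-fold higher number from compound 2 to compound 3 (1.98 log units; beyond the scatter) in a single small change. The second of these steps is the more telling, since acetyl and carboxy both carry a carbonyl at this aromatic carbon and yet stand at opposite ends of the series, with 1-hydroxyethyl between them. A carbonyl alone therefore does not secure a low number here, and the group attached to it matters a great deal.

What the compounds shown leave open is where a primary amide, a methyl ester or a longer ketone such as propanoyl would fall between acetyl and carboxy. They also leave open whether this order of groups would hold on a different core. Nothing available here accounts for why these three groups rank as they do.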